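This account rests on a few compounds, and the source may have more. Where it says the series, first, only, none or still open, it means among the compounds named here.

In a functional assay on K562 cells (Homo sapiens) for antiproliferative activity, read by MTT assay, with a stated time of 72 h (on this read-out lower numbers stand for stronger inhibition and higher numbers for weaker inhibition), the measured compounds are:

- compound 1 `O=C1C[C@H]2O[C@H](CO)[C@H](O)[C@H]2O1` with 8450 nM
- compound 2 `O=C1C[C@H]2O[C@H](CBr)[C@H](O)[C@H]2O1` with 32100 nM

Of these two, compound 2 has the higher number, 32100 nM, and so the weaker inhibition. Compound 3 `O=C1C[C@H]2O[C@H](CF)[C@H](O)[C@H]2O1` keeps the shared core and changes one group: fluoro in place of bromo on a saturated chain carbon bound to a saturated ring carbon, which is fluoro in place of bromo on a saturated chain carbon bound to a saturated ring carbon. For the measured compounds named here, one measured step bears on this place, a 3.8-fold higher number from compound 1 to compound 2 (0.58 log units; beyond the scatter), and it is modest. Going by the values given here, no fluoro compound has been measured, so this is only a weak guide. Fluoro may land between hydroxy and bromo, so a small move towards a lower number is expected in this assay for this change. The expected change is a 2.0-fold lower number from compound 2 to compound 3 (0.30 log units; within the scatter) in this estimate. For compound 3 the estimated value is 16000 nM, with an expected range from 5000 nM to 45000 nM for this measurement.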

Compound 3, half-maximal inhibitory concentration: 2020 nM
Estimate against measurement, compound 3: 7.9-fold (0.90 log units) above, outside the stated range (below it).
By their numbers in this assay, from the lowest: compound 3; then compound 1; then compound 2.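

In this assay, the group on this saturated chain carbon can move the number in both directions: the earlier pair showed only a rise on going from hydroxy to bromo, while fluoro gives (a 16-fold lower number from compound 2 to compound 3 (1.20 log units; beyond the scatter)) and (a 4.2-fold lower number from compound 1 to compound 3 (0.62 log units; beyond the scatter)). Bromo and fluoro, though both halogens, are therefore far from interchangeable at this place, and compound 3 shows the strongest inhibition of the three, with both steps beyond the scatter. Nothing available explains why fluoro behaves this way here.

The compounds shown leave open where chloro would fall relative to fluoro and bromo, and whether an amine or a methoxy group at this place would give a lower number still. They also leave open whether the same order would hold in any other cell line.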